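Replacing the pyrimidinyl group on a thiazole core

The source may report more compounds than this note shows. Statements on the series, on what has been measured and on what is new or still open speak of the compounds shown alone.

Measured compounds in an assay on blood for inhibition of C-X-C chemokine receptor type 3 (Homo sapiens), with a stated time of 30 min; on this read-out lower numbers stand for stronger inhibition and higher numbers for weaker inhibition:
Compound 1, `CCCc1ncc(-c2nc(C(F)(F)F)sc2N2CCN(C(=O)Cn3nc(C)nc3C)[C@H](C)C2)cn1`, gives 367 nM.
Compound 2, `Cc1nc(C)n(CC(=O)N2CCN(c3sc(C(F)(F)F)nc3-c3cnc(N4CCCC4)nc3)C[C@H]2C)n1`, gives 352 nM.

Compound 2 and compound 1 share one core and differ only in the group on an aromatic carbon of the pyrimidine. Going by the values given here, the one step that joins them, a 1.0-fold lower number from compound 1 to compound 2 (0.02 log units; within the scatter), lies within the scatter, so the two numbers cannot be told apart; compound 2 does not stand out from compound 1 in this assay.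

Compound 3, `COc1ccc(-c2nc(C(F)(F)F)sc2N2CCN(C(=O)Cn3nc(C)nc3C)[C@H](C)C2)cn1`, has not been measured in this assay. It differs from compound 2 in one place: 6-methoxypyridin-3-yl in place of 2-(pyrrolidin-1-yl)pyrimidin-5-yl on an aromatic carbon. Among the compounds with values here, the only measured step, that from compound 1 to compound 2, swapped the group on the pyrimidine while keeping the ring; here the ring itself changes as well. That step bears on the question only loosely and was within the scatter, so there is no basis in the numbers for a step of any size in this assay. Compound 3 is therefore expected to give about 450 nM, with a broad range from 150 nM to 1500 nM, which corresponds to an expected step of a 1.3-fold higher number from compound 2 to compound 3 (0.11 log units; within the scatter).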

Compound 3, half-maximal inhibitory concentration: 1580 nM
For compound 3 the middle estimate is 3.5-fold (0.55 log units) below the measured one; the measured number lies above the stated range.
By their numbers in this assay, from the lowest: compounds 2 and 1 (each within the scatter of the next); then compound 3.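

The group on this aromatic carbon of the five-membered aromatic ring does matter in this assay: changing the substituent on the pyrimidine had left the numbers within the scatter, but exchanging the whole group for 6-methoxypyridin-3-yl gives a 4.5-fold higher number from compound 2 to compound 3 (0.65 log units; beyond the scatter) and, against the propyl analogue, a 4.3-fold higher number from compound 1 to compound 3 (0.63 log units; beyond the scatter). Both steps lie beyond the scatter and are close in size, so among these three compounds the two pyrimidine-bearing compounds stand together, with compound 3 the weakest of the set. The compounds shown offer no measured reason for this loss of inhibition.

Compound 3 differs from the other two in both the ring and its substituent, so the compounds shown cannot tell whether the loss follows the pyridine ring, the methoxy group or the two together. A 2-methoxypyrimidin-5-yl group or a 6-(pyrrolidin-1-yl)pyridin-3-yl group would separate those two changes, while a dimethylamino group or a longer alkyl chain on the pyrimidine would test how far the substituent can vary before the number moves.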